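Chalcone-maleimide pair: aryl substituent and cytotoxicity

The source may hold more compounds than are shown below. What is called first, only, known or untested is meant among the compounds shown, and "the series" means these compounds.

Measured so far:
compound 1 `O=C(/C=C/c1ccc(Cl)cc1)c1ccc(N2C(=O)C=CC2=O)cc1`: 7500 nM
compound 2 `COc1ccc(/C=C/C(=O)c2ccc(N3C(=O)C=CC3=O)cc2)cc1OC`: 220000 nM

In a functional assay on CCRF-CEM cells (Homo sapiens) for cytotoxicity (on this read-out higher numbers stand for weaker inhibition and lower numbers for stronger inhibition), compound 1 gives 7500 nM, the lowest of the two numbers recorded; compound 2 stands at 220000 nM, a gap beyond the scatter. The next compound, compound 3 `O=C(O)c1ccc(/C=C/C(=O)c2ccc(N3C(=O)C=CC3=O)cc2)cc1`, is not yet measured. It differs from compound 1 as carboxy in place of chloro on an aromatic carbon. Within the data shown here, no measured pair shows this exact change, so the expectation rests only on compound 1 and its value. A step toward a higher number is expected, as a 5.3-fold higher number from compound 1 to compound 3 (0.73 log units; beyond the scatter) in this assay. For compound 3 the estimate is 40000 nM, with a range from 8000 nM to 200000 nM.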

Compound 3, half-maximal inhibitory concentration: 133000 nM
Compound 3: the middle estimate sits 3.3-fold (0.52 log units) below what was measured, within the range that was stated.
By their numbers in this assay, from the lowest: compound 1; then compounds 3 and 2 (each within the scatter of the next).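

In this assay, among these compounds, carboxy in place of chloro on an aromatic carbon gives the first single-place step, an 18-fold higher number from compound 1 to compound 3 (1.25 log units; beyond the scatter), and it is large. The substituent at this position, para to a large group, therefore matters to the read-out, with chloro holding the lower number. Nothing measured here accounts for the step.

A single step cannot separate the loss of chloro from the arrival of carboxy. Going by these compounds, whether a methyl ester, an amine or fluoro at this position would track compound 1 or compound 3 remains open.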